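This account rests on a few compounds, and the source may have more. Where it says the series, first, only, none or still open, it means among the compounds named here.

Compound 1 `O=C1/C(=C/c2ccccc2)CN(C(=O)CCSCCS(=O)(=O)O)C/C1=C\c1ccccc1` carries a sulfo group, and in a functional assay on HSC-2 cells (Homo sapiens) for cytotoxicity, read by MTT assay, with a stated time of 48 h (on this read-out higher numbers stand for lower toxicity in this test and lower numbers for higher toxicity in this test), compound 1 gives 154000 nM. Compound 2 `O=C1/C(=C/c2ccccc2)CN(C(=O)CCSCCO)C/C1=C\c1ccccc1` differs from it by hydroxy in place of sulfo on a saturated chain carbon, two bonds along the chain from a sulfur, and in this assay compound 2 gives 1530 nM, so that a 100-fold lower number from compound 1 to compound 2 (2.00 log units; beyond the scatter). Compound 3 `COc1ccc(/C=C2\CN(C(=O)CCSCCS(=O)(=O)O)C/C(=C\c3ccc(OC)cc3)C2=O)cc1` rests on a different core; the difference between the two cores is not broken down here. In this assay compound 3 gives 91700 nM, a number close to that of compound 1. Compound 4 `COc1ccc(/C=C2\CN(C(=O)CCSCCO)C/C(=C\c3ccc(OC)cc3)C2=O)cc1` has not yet been measured and differs from compound 3 by hydroxy in place of sulfo on a saturated chain carbon, two bonds along the chain from a sulfur, the same change at the same place as that between compound 1 and compound 2. Because the earlier step of a 100-fold lower number from compound 1 to compound 2 (2.00 log units; beyond the scatter) was large and compound 3 sits near compound 1, compound 4 is expected to show a 92-fold lower number from compound 3 to compound 4 (1.96 log units; beyond the scatter). The estimate for compound 4 in this assay is therefore 1000 nM, expected between 300 nM and 5000 nM.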

Compound 4, half-maximal cytotoxic concentration: 2670 nM
Beside the measured number, compound 4's estimate is 2.7-fold (0.43 log units) below it; measured number inside the range.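

In this assay the change on the second core gives a 34-fold lower number from compound 3 to compound 4 (1.54 log units; beyond the scatter) and so runs the same way as on the first core. The direction carries over between these two cores, but the size of the step does not carry over unchanged: the same change on two cores in this assay, a 100-fold lower number (2.00 log units; beyond the scatter) from compound 1 to compound 2 and a 34-fold lower number (1.54 log units; beyond the scatter) from compound 3 to compound 4, 2.9-fold (0.47 log units) apart, beyond the scatter of two such steps. Among the compounds shown here, with only two pairs, this shows neither how the step would run on any further core nor which feature of the cores goes with the gap.

The compounds shown leave open how a carboxylic acid or an amine at this place on the chain would read in this assay. They also leave open how a longer chain carrying the hydroxy would read.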